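Swapping heptyl for 2-methoxyethoxy on a carbonyl carbon

The source may report more compounds than this note shows. Statements on the series, on what has been measured and on what is new or still open speak of the compounds shown alone.

In a functional assay on WI-38 VA13 cells (Homo sapiens) for cytotoxicity (a higher number here means that more compound is needed for the effect, a lower number that less compound is needed), compound 1 `O=C(Nc1ccc2nc(NC(=O)C3CCCCC3)sc2c1)c1cccnc1Cl` gives 0.075 ug/mL and compound 2 `CCCCCCCC(=O)Nc1nc2ccc(NC(=O)c3c(Cl)cccc3Cl)cc2s1` gives 0.18 ug/mL as the higher of the two numbers, a gap beyond the usual scatter. Compound 3 `COCCOC(=O)Nc1nc2ccc(NC(=O)c3c(Cl)cccc3Cl)cc2s1` is still unmeasured. It carries 2-methoxyethoxy in place of heptyl on a carbonyl carbon. Within the data shown here, no measured pair shows this change, so only a modest rise in this assay is expected, and with little certainty. The estimated move is a 1.7-fold higher number from compound 2 to compound 3 (0.22 log units; within the scatter) in size. For compound 3 the expected value is 0.3 ug/mL with 0.06 ug/mL and 1.5 ug/mL as the ends of its likely range.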

Compound 3, half-maximal effective concentration: 0.011 ug/mL
For compound 3 the middle estimate is 27-fold (1.44 log units) above the measured one, outside the stated range (below it).
By their numbers in this assay, from the lowest: compound 3; then compound 1; then compound 2.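

In this assay, putting 2-methoxyethoxy in place of heptyl on a carbonyl carbon gives a 16-fold lower number from compound 2 to compound 3 (1.21 log units; beyond the scatter). This shows that the group at this position can strongly change the amount of compound needed, something compound 1 and compound 2 could not show, as they differ in more than one place. Nothing available explains why the number falls. Going by these compounds, it remains open which part of the 2-methoxyethoxy group matters: a butoxy group on the same carbonyl carbon would test the oxygen within the chain, and a 2-aminoethoxy group would test an amine there.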